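Methoxycarbonyl to carboxy: working notes on the series

The source may hold more compounds than are shown below. What is called first, only, known or untested is meant among the compounds shown, and "the series" means these compounds.

Measured so far:
- compound 1 `COC(=O)CCCCCCC(=O)Nc1cccc(OS(=O)(=O)C2CC3OC2C(c2ccc(O)cc2)=C3c2ccc(O)cc2)c1`: 19100 nM
- compound 2 `O=C(O)CCCCCCC(=O)Nc1ccc(OS(=O)(=O)C2CC3OC2C(c2ccc(O)cc2)=C3c2ccc(O)cc2)cc1`: 19100 nM

In a functional assay on MCF7 cells (Homo sapiens) for inhibition, read by MTT assay, with a stated time of 72 h (on this read-out higher numbers stand for weaker inhibition and lower numbers for stronger inhibition), compound 1 gives 19100 nM, level with compound 2 at 19100 nM. Going by the values given here, the two values lie within the scatter, and these are the only two numbers available for the series.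

The next entry is compound 3 `O=C(O)CCCCCCC(=O)Nc1cccc(OS(=O)(=O)C2CC3OC2C(c2ccc(O)cc2)=C3c2ccc(O)cc2)c1`, which has not yet been measured. Going from compound 1 to compound 3 puts hydrogen in place of methyl on an oxygen next to a carbonyl group, so methoxycarbonyl becomes carboxy. Among the compounds with values here, no measured pair isolates this change, so its size cannot be read from the data. With compound 1 at 19100 nM as the only anchor, no step beyond the scatter is expected in this assay, and no direction is favoured. The expected step of a 1.0-fold lower number from compound 1 to compound 3 (0.00 log units; within the scatter) is therefore small, with wide uncertainty. The estimate for compound 3 is 19000 nM, with an expected range from 8000 nM to 45000 nM.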

Compound 3, half-maximal inhibitory concentration: > 100000 nM
Compound 3 gave a limit, no number; the forecaster's own chance of this, stated with the estimate: 10%; at least 5.2-fold (0.72 log units) between middle value and limit.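

In this assay, putting hydrogen in place of methyl on an oxygen next to a carbonyl group, so that methoxycarbonyl becomes carboxy, gives an at least 5.2-fold higher number from compound 1 to compound 3 (0.71 log units; beyond the scatter). Going by these compounds alone, this is the only step that isolates a single change, and it shows that the read-out is not indifferent to this end of the chain: removing one methyl is enough to move it beyond the scatter, towards weaker inhibition. Compound 3 gives only a limit of the assay, not a number, so the step has a lower bound but no measured size: the limit of > 100000 nM in this assay, at which 1 of the 3 values shown sits.

Compound 2 also carries carboxy and gives 19100 nM, so carboxy does not go with weak inhibition in every compound shown, and the change cannot be generalised beyond this one pair. Still open, as far as these compounds go, is how ethoxycarbonyl, a primary amide or a longer chain ending in methoxycarbonyl would read in this assay, and whether any of these stays close to compound 1 or falls away as compound 3 does.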